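The compounds below may be only part of what the source reports. "The series", "measured", "known", "first", "only" and "open" are said of these compounds alone.

Measured in a physicochemical assay for lipophilicity, read by HPLC, tested at 5 mM; a lower number here means a more polar compound, a higher number a more lipophilic compound:
- Compound 1 `CCCCCCCCc1ccc(OC(C)C(=O)Cn2nnc(-c3ccc(Cl)cc3)n2)cc1`: > 8 (a limit, not a number)
- Compound 2 `CC(Oc1ccc(Oc2ccc(F)cc2)cc1)C(=O)Cn1nnc(-c2ccc(Cl)cc2)n1`: 6.2
- Compound 3 `CC(Oc1ccc(-c2ccccc2)cc1)C(=O)Cn1nnc(-c2ccc(Cl)cc2)n1`: 6.1

Compound 1 has only a limit in this assay: the limit of > 8 in this assay, at which 1 of the 3 values shown sits.

Compound 4 `CCCCCCCCc1ccc(OC(C)C(=O)Cn2nnc(-c3ccc(C(=O)O)cc3)n2)cc1` differs from compound 1 in one place: carboxy in place of chloro on an aromatic carbon. This is carboxy in place of chloro on an aromatic carbon, so 4-chlorophenyl becomes 4-carboxyphenyl.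

Within the data shown here, no measured step touches the chloro group. The two large steps, a number at least 1.80 log units lower from compound 1 to compound 2 (beyond the scatter) and a number at least 1.90 log units lower from compound 1 to compound 3 (beyond the scatter), both replace octyl, and they serve only as a scale for what one change can do in this series. The third, a number 0.10 log units lower from compound 2 to compound 3 (within the scatter), stays within the scatter.

The carboxy group brings in a hydrogen-bond donor and acceptor, and the chloro group takes none away, so a drop beyond the scatter is expected, of a size comparable to those two large steps. The expected change is a number at least 1.40 log units lower from compound 1 to compound 4 (beyond the scatter). For compound 4 the estimated value is 6.6, with an expected range from 5.6 to 7.6.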

Compound 4, partition coefficient: 5.9
Estimate against measurement, compound 4: 0.70 log units above, within the range that was stated.
By their numbers in this assay, from the lowest: compounds 4, 3 and 2 (each within the scatter of the next). At a limit, above all of these: compound 1.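

In this assay, the chloro group had not been touched by any earlier step, and this position now has a step of its own: a number at least 2.10 log units lower from compound 1 to compound 4 (beyond the scatter). With octyl kept, a single change on this aromatic carbon therefore gives a large step, as the replacements of octyl by 4-fluorophenoxy and phenyl did at their own position. The step is a bound and not an exact size because compound 1 stands at a limit, not a number: the limit of > 8 in this assay, at which 1 of the 4 values shown sits.

Still open, as far as these compounds go, is whether carboxy in place of chloro gives a step of similar size on compound 2 or compound 3, each of which has a number and not a limit. Also open, from the compounds shown here alone, is how an amine, a primary amide or a methyl ester would read on this same aromatic carbon.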